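This account rests on a few compounds, and the source may have more. Where it says the series, first, only, none or still open, it means among the compounds named here.

Compound 1, `CCOC(=O)c1cc(=O)c2cc(CSC(=S)N(C)c3ccccc3)ccc2o1`: > 25000 nM
Compound 2, `O=c1c(CSC(=S)N2CCCC2)coc2cc(Cl)ccc12`: 600 nM

Of the compounds shown here, two have been measured in a functional assay on MCF7 cells (Homo sapiens) for antiproliferative activity, read by MTT assay, with a stated time of 72 h; a lower number here means a stronger inhibitor, a higher number a weaker inhibitor. For compound 1 the result is a limit of the assay rather than a number, > 25000 nM, the situation described by the limit of > 25000 nM in this assay, at which 1 of the 2 values shown sits. Compound 2, built on a different core, gives 600 nM in this assay, a measured number. Compound 3, `CCOC(=O)c1cc(=O)c2cc(CSC(=S)N3CCCCC3)ccc2o1`, has not yet been tested. It shares the core of compound 1 and differs from it in one place: piperidin-1-yl in place of methyl(phenyl)amino on a thiocarbonyl carbon. Within the data shown here, no step between two measured compounds shows what this exchange does on its own, so an expectation can rest only on the limit seen for compound 1 and on the value of compound 2, which, as its structure shows, also carries no methyl(phenyl)amino group. A move from the limit toward a measured number is expected, of the size an at least 4.1-fold lower number from compound 1 to compound 3 (0.61 log units; beyond the scatter), though a limit for compound 3 remains possible. Compound 3 is estimated at 6000 nM, in a range from 1500 nM to 25000 nM.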

Compound 3, half-maximal inhibitory concentration: 21900 nM
Estimate against measurement, compound 3: 3.7-fold (0.56 log units) below, within the range that was stated.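

In this assay, among these compounds, compound 3 gives 21900 nM, which shows that the core of compound 1 can yield a measured number when the thiocarbonyl carbon carries piperidin-1-yl, something the earlier compounds could not show. Read as a step, piperidin-1-yl in place of methyl(phenyl)amino gives an at least 1.1-fold lower number from compound 1 to compound 3 (0.05 log units; that floor lies within the scatter), so the data do not establish a real gain from this exchange. Compound 1 stands at a limit of the assay and not at a number, so the true size of the step cannot be read: the limit of > 25000 nM in this assay, at which 1 of the 3 values shown sits.

Still open, on these data alone, is how this core would respond to other amines on the thiocarbonyl carbon, such as morpholin-4-yl or diethylamino, and whether any of them would give a step clearly beyond the scatter. Also open, as far as these compounds go, is what a carboxylic acid in place of the ethyl ester would do, while compound 2 differs from compound 3 in more than one place and so cannot settle either question.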